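A Benzyl Aryl Swap from Compound 1 to Compound 4

The source may report more compounds than this note shows. Statements on the series, on what has been measured and on what is new or still open speak of the compounds shown alone.

Compound 1 `Cc1cccc(CSc2cc(Cl)c(C)cc2S(=O)(=O)/N=C(\N)n2nccc2-c2ccccc2)c1` gives 6500 nM in a functional assay on HCT-116 cells (Homo sapiens) for cytotoxicity, read by MTT assay, with a stated time of 72 h; a lower number here means a stronger inhibitor, a higher number a weaker inhibitor.
Compound 2 `Cc1cc(-c2ccccc2)n(/C(N)=N/S(=O)(=O)c2cc(C)c(Cl)cc2SCc2cccc3ccccc23)n1` gives 7000 nM in this assay.
Compound 3 `Cc1cccc(CSc2cc(Cl)c(C)cc2S(=O)(=O)/N=C(\N)n2nc(C)cc2-c2ccccc2)c1` gives 34000 nM in this assay.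

Compound 1 holds the lowest number of the three, though compound 2 sits within the scatter of it; compound 3 lies beyond it, a 5.2-fold higher number from compound 1 to compound 3 (0.72 log units; beyond the scatter). Compound 4 `Cc1cc(S(=O)(=O)/N=C(\N)n2nccc2-c2ccccc2)c(SCc2ccc(C(F)(F)F)cc2)cc1Cl` arises from compound 1 by the change (4-(trifluoromethyl)phenyl in place of 3-methylphenyl on a saturated chain carbon bound to a sulfur). The same place was changed once before, a 4.9-fold higher number from compound 2 to compound 3 (0.69 log units; beyond the scatter), a modest step, while compounds 1 and 2, which differ only there, lie within the scatter of each other. An aryl swap here is therefore expected to move this assay little, a 1.1-fold higher number from compound 1 to compound 4 (0.03 log units; within the scatter), with no direction favoured. Compound 4 is estimated at 7000 nM, between 3000 nM and 17000 nM.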

Compound 4, half-maximal inhibitory concentration: 14000 nM
Beside the measured number, compound 4's estimate is 2.0-fold (0.30 log units) below it, within the range that was stated.
By their numbers in this assay, from the lowest: compounds 1, 2 and 4 (each within the scatter of the next, the first and the last beyond it); then compound 3.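

On the core of compound 1, which has hydrogen where compound 3 carries its added methyl, this aryl swap gives a measurable change in this assay: a 2.2-fold higher number from compound 1 to compound 4 (0.33 log units; beyond the scatter). The position is therefore not indifferent to the aryl group on this core, although the step is modest and compound 4 remains measurable in the same assay. Nothing shown here accounts for the step.

The compounds shown leave open how a phenyl bearing an amine or a carboxylic acid would read at this place. They also leave open what a longer chain on the sulfur would do.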